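A few compounds are considered here, and "the series" means these few. Any claim that something is new, unique, unknown or untested is made for them only; others in the source may bear on it.

Compound 1 `N#Cc1ccc(C(=O)NC(=O)c2ccccc2O)cc1` gives 55 ug/mL in an ADME assay on L6 cells (Rattus norvegicus) for cytotoxicity, read by resazurin assay, with a stated time of 72 h; on this read-out higher numbers stand for weaker inhibition and lower numbers for stronger inhibition
Compound 2 `COC(=O)c1ccc(C(=O)NC(=O)c2ccccc2O)cc1` gives 42 ug/mL in this assay

On these numbers compound 2 cannot be told apart from compound 1, since the two differ by a 1.3-fold lower number from compound 1 to compound 2 (0.12 log units; within the scatter) and nothing more. That pair differs only in the group on one aromatic carbon, with cyano in one and methoxycarbonyl in the other.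

The unmeasured compound 3 `CN(C)c1ccc(C(=O)NC(=O)c2ccccc2O)cc1` changes that same carbon of compound 2. The difference is dimethylamino in place of methoxycarbonyl on an aromatic carbon and, in short, dimethylamino takes the place of methoxycarbonyl.

Going by the values given here, only one measured step bears on this change, and it is the small one, a 1.3-fold lower number from compound 1 to compound 2 (0.12 log units; within the scatter) on the same carbon. Among the compounds with values here, it is thin evidence, as no measured compound carries dimethylamino. Even so, the one swap seen at this carbon stayed within the scatter, so no shift beyond the scatter is expected in this assay here. The expected step is a 1.2-fold lower number from compound 2 to compound 3 (0.08 log units; within the scatter) and would not be a real change. For compound 3 the estimated value is 35 ug/mL, within an expected range of 14 ug/mL to 80 ug/mL, kept wide for want of closer comparisons.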

Compound 3, half-maximal inhibitory concentration: 54 ug/mL
Estimate against measurement, compound 3: 1.5-fold (0.19 log units) below; measured number inside the range.
By their numbers in this assay, from the lowest: compounds 2, 3 and 1 (each within the scatter of the next).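

In this assay, putting dimethylamino on this aromatic carbon gives no real shift: the result is a 1.3-fold higher number from compound 2 to compound 3 (0.11 log units; within the scatter) and, measured against the cyano compound's partner step, a 1.0-fold lower number from compound 1 to compound 3 (0.01 log units; within the scatter) on the same carbon. The earlier pair could speak only for cyano and methoxycarbonyl, whereas three different groups have now been compared at this carbon, para to a large group, and none can be told apart from the others in this cell read-out, even though methoxycarbonyl and dimethylamino differ in their heavy atoms and hydrogen-bond acceptor counts. Nothing available explains this flat result.

The compounds shown leave open whether a different kind of group on this carbon, such as a carboxylic acid, a primary amine or a longer alkyl chain, would move the number beyond the scatter. As far as these compounds go, all three compounds differ only at this one carbon, so what a change elsewhere on the shared core would do also remains open.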